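Working notes: from compound 3 to compound 4

The source may hold more compounds than are shown below. What is called first, only, known or untested is meant among the compounds shown, and "the series" means these compounds.

Measured so far:
compound 1 `CN(C)C(=O)c1cc2cnc(Nc3ccc(S(=O)(=O)NCCCCCN=C=S)cc3)nc2n1C1CCCC1` gives 52.1%
compound 2 `CN(C)C(=O)c1cc2cnc(Nc3ccc(C(=O)NCCCCN=C=S)cc3)nc2n1C1CCCC1` gives 55.2%
compound 3 `CN(C)C(=O)c1cc2cnc(Nc3ccc(NC(=O)CCCCCCN=C=S)cc3)nc2n1C1CCCC1` gives 50.9%

In a functional assay on NCI-H1299 cells (Homo sapiens) for inhibition, read by CCK-8 assay, with a stated time of 72 h, tested at 1 uM (a lower number here means a weaker effect, a higher number a stronger effect of the compound at the concentration tested), compound 3 holds the lowest of the three numbers, though a number 1.2 percentage points lower from compound 1 to compound 3 (within the scatter) and a number 4.3 percentage points lower from compound 2 to compound 3 (within the scatter) both sit within the scatter, so no order among the three can be read. Compound 4 `CN(C)C(=O)c1cc2cnc(Nc3ccc(N=C=S)cc3)nc2n1C1CCCC1` differs from compound 3 by a group of 3 heavy atoms (1 carbon, 1 nitrogen, 1 sulfur; no ring) in place of a group of 12 heavy atoms (8 carbon, 2 nitrogen, 1 oxygen, 1 sulfur; no ring), on an aromatic carbon. The measured steps of a number 3.1 percentage points higher from compound 1 to compound 2 (within the scatter), a number 1.2 percentage points lower from compound 1 to compound 3 (within the scatter) and a number 4.3 percentage points lower from compound 2 to compound 3 (within the scatter) each exchange one chain for another of similar length and all stayed within the scatter; none removes the chain altogether, so they bear on this step only loosely. The expectation is still a step of a number 0.9 percentage points lower from compound 3 to compound 4 (within the scatter), nothing beyond the scatter, with widened uncertainty. Compound 4 is estimated at 50%, between 33% and 67%.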

Compound 4, a percentage reported as inhibition, at one concentration (the size of the read-out at that concentration, not a potency): 46.9%
Estimate against measurement, compound 4: 3.1 percentage points above, and the stated range covers the measured number.
By their numbers in this assay, from the lowest: compounds 4, 3, 1 and 2 (each within the scatter of the next).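

In this assay the group of 3 heavy atoms, sitting directly on the aromatic carbon with no chain, stays within the scatter of all three chain-bearing compounds, with a number 4 percentage points lower from compound 3 to compound 4 (within the scatter) and a number 8.3 percentage points lower from compound 2 to compound 4 (within the scatter) and a number 5.2 percentage points lower from compound 1 to compound 4 (within the scatter) as the steps. At this position the chains of compound 1, compound 2 and compound 3 can therefore be removed without a readable difference at this single concentration. No evidence is available to explain this result.

As far as these compounds go, whether the group of 3 heavy atoms can itself be replaced, for example by an amine or a carboxylic acid, remains open. From the compounds shown here alone, a longer chain on the same aromatic carbon also remains open.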